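A Methoxy Variant on the Shared Core

A few compounds are considered here, and "the series" means these few. Any claim that something is new, unique, unknown or untested is made for them only; others in the source may bear on it.

Compound 1 `Cc1nn(-c2ccccc2)c2nc(C(=O)N3NC(=O)/C(=C/c4ccccc4)N=C3c3ccccc3)[nH]c(=O)c12` serves as the reference point. Within the data shown here, in an ADME assay on WI-38 cells (Homo sapiens) for cytotoxicity, read by MTT assay, with a stated time of 48 h (a lower number here means a stronger inhibitor, a higher number a weaker inhibitor), compound 1 gives 49.5 nM, the second highest of the three numbers measured so far. Its closest neighbour is compound 2 `Cc1nn(-c2ccccc2)c2nc(C(=O)N3NC(=O)/C(=C/c4ccccc4)N=C3c3ccc(Cl)cc3)[nH]c(=O)c12`, which carries a chloro in place of hydrogen on an aromatic carbon; in this assay compound 2 gives 55 nM, and the step of a 1.1-fold higher number from compound 1 to compound 2 (0.05 log units; within the scatter) shows that this exchange left the number essentially unchanged. Compound 3 `Cc1ccc(C2=N/C(=C\c3ccccc3)C(=O)NN2C(=O)c2nc3c(c(C)nn3-c3ccccc3)c(=O)[nH]2)cc1` carries a methyl in place of hydrogen on an aromatic carbon; in this assay compound 3 gives 24.5 nM. The step of a 2.0-fold lower number from compound 1 to compound 3 (0.31 log units; beyond the scatter) and the step of a 2.2-fold lower number from compound 2 to compound 3 (0.35 log units; beyond the scatter) are both modest but beyond the scatter.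

Compound 4 `COc1ccc(/C=C2\N=C(c3ccccc3)N(C(=O)c3nc4c(c(C)nn4-c4ccccc4)c(=O)[nH]3)NC2=O)cc1` differs from compound 1 by methoxy in place of hydrogen on an aromatic carbon. The two measured steps that bear on it are the chloro step and the methyl step, each a single group entering a six-membered aromatic ring of carbon only: one within the scatter, one a modest lowering. A methoxy entering in the same fashion is therefore expected to move the number little, if anything slightly downward. Compound 4 is expected to give 40 nM in this assay, within a range from 20 nM to 90 nM, which corresponds to an expected step of a 1.2-fold lower number from compound 1 to compound 4 (0.09 log units; within the scatter).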

Compound 4, half-maximal inhibitory concentration: 97.7 nM
For compound 4 the middle estimate is 2.4-fold (0.39 log units) below the measured one, outside the stated range (above it).
By their numbers in this assay, from the lowest: compound 3; then compounds 1, 2 and 4 (each within the scatter of the next).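

In this assay, among these compounds, the change from phenyl to 4-methoxyphenyl gives the first reading at this place, on a different phenyl ring from the one that carries the chloro of compound 2 and the methyl of compound 3, so the earlier steps had not tested this ring directly. Among the compounds shown here, the reading (a 2.0-fold higher number from compound 1 to compound 4 (0.30 log units; within the scatter)) lies within the scatter, which means that a methoxy para to a large group cannot be told apart from the hydrogen it replaces, and the lowering seen with methyl on the other ring (a 2.0-fold lower number from compound 1 to compound 3 (0.31 log units; beyond the scatter)) finds no counterpart here. Nothing available here accounts for the number of compound 4.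

The compounds shown leave open whether a hydroxyl, an amine or a carboxylic acid at this same place would give a number clearly apart from that of compound 1. They also leave open whether a chloro or a methyl on this ring would behave as it does on the other phenyl ring, and whether a methoxy on that other ring would match the reading seen here.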